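The source may report more compounds than this note shows. Statements on the series, on what has been measured and on what is new or still open speak of the compounds shown alone.

Measured compounds:
- compound 1, `Nc1nn2c(O)cc(-c3cc([N+](=O)[O-])c(Cl)cc3Cl)nc2c1[N+](=O)[O-]`: > 100 ug/mL
- compound 2, `Nc1nn2c(O)cc(CCl)nc2c1[N+](=O)[O-]`: > 50 ug/mL

In an ADME assay (Homo sapiens) for cytotoxicity (a higher number here means that more compound is tolerated, a lower number that less compound is tolerated), compound 2 gives > 50 ug/mL, which is a limit of the assay and not a number. Compound 1 gives > 100 ug/mL in this assay, again a limit rather than a number. Both values shown are therefore limits, one sitting at the limit of > 50 ug/mL in this assay, at which 1 of the 2 values shown sits, and the other at the limit of > 100 ug/mL in this assay, at which 1 of the 2 values shown sits; where compound 2 stands within the series can only be said to this extent, that no measured number lies anywhere in the set. Among the measured compounds shown here, no step between measured compounds that differ in one place exists in these data.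

Compound 3, `Nc1nn2c(O)cc(CNNC(N)S)nc2c1[N+](=O)[O-]`, has not been measured in this assay. Relative to compound 2 the change is ((amino(sulfanyl)methyl)amino)amino in place of chloro on a saturated chain carbon bound to an aromatic carbon. For the measured compounds named here, with no measured step to lean on, the step from compound 2 to compound 3 in this assay is expected to be none beyond the scatter, as a step that the limit leaves unreadable from compound 2 to compound 3. For compound 3 the expected value in this assay is 80 ug/mL, with a range from 30 ug/mL to 200 ug/mL, and a report of only a limit is thought more likely than a number.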

Compound 3, half-maximal cytotoxic concentration: > 50 ug/mL
Compound 3: no number, only a limit (the forecaster's own chance of this, stated with the estimate: 60%); the middle value does not contradict the limit.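

No step can be read from compound 2 to compound 3 in this assay: both results are limits of the assay and not numbers. The compounds shown leave open what measured number any of them would give, and whether ((amino(sulfanyl)methyl)amino)amino in place of chloro changes the result at all.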